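Hydrazone aryl swaps on the triazine sulfonamide series

The compounds below may be only part of what the source reports. "The series", "measured", "known", "first", "only" and "open" are said of these compounds alone.

Measured so far:
compound 1, `NS(=O)(=O)c1ccc(Nc2nc(N/N=C/c3ccc(C(F)(F)F)cc3)nc(Nc3ccccc3)n2)cc1` — 16200 nM
compound 2, `Cc1nn(-c2ccccc2)cc1/C=N/Nc1nc(Nc2ccccc2)nc(Nc2ccc(S(N)(=O)=O)cc2)n1` — 7190 nM

Both compounds were measured in a functional assay on UACC-62 cells (Homo sapiens) for inhibition, read by sulforhodamine B assay, with a stated time of 48 h; on this read-out lower numbers stand for higher toxicity in this test and higher numbers for lower toxicity in this test. Among the measured compounds shown here, compound 2 holds the lower of the two numbers; compound 1 sits above it by the single step of a 2.3-fold lower number from compound 1 to compound 2 (0.35 log units; beyond the scatter), which exchanges the aryl group on the hydrazone carbon.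

The next compound is compound 3, `NS(=O)(=O)c1ccc(Nc2nc(N/N=C/c3ccccn3)nc(Nc3ccccc3)n2)cc1`. Its change from compound 2 is pyridin-2-yl in place of 3-methyl-1-phenyl-1H-pyrazol-4-yl on a carbon with a double bond to nitrogen. For the measured compounds named here, this is again a swap of the aryl group on the hydrazone carbon, the same place as in the one step measured. Going by the values given here, that step, a 2.3-fold lower number from compound 1 to compound 2 (0.35 log units; beyond the scatter), was modest and only just beyond the scatter, and it went from a six-membered carbon ring to the pyrazolyl group; the present change goes the other way in ring size and there is no measured example of a pyridin-2-yl at this place. The expectation for compound 3 is therefore a small step back toward compound 1, a 1.5-fold higher number from compound 2 to compound 3 (0.18 log units; within the scatter), with wide uncertainty. Compound 3 is estimated at 11000 nM, range 4000 nM to 30000 nM.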

Compound 3, concentration lethal to 50% of the cells: 6150 nM
Compound 3: middle estimate off by 1.8-fold (0.25 log units), on the high side; measured number inside the range.
By their numbers in this assay, from the lowest: compounds 3 and 2 (each within the scatter of the next); then compound 1.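

In this assay, pyridin-2-yl in place of 3-methyl-1-phenyl-1H-pyrazol-4-yl on the carbon with a double bond to nitrogen gives a 1.2-fold lower number from compound 2 to compound 3 (0.07 log units; within the scatter) and so does not separate the two groups, although the entering group has fewer heavy atoms than the leaving group. Against the 4-(trifluoromethyl)phenyl of compound 1, the same pyridin-2-yl gives a 2.6-fold lower number from compound 1 to compound 3 (0.42 log units; beyond the scatter) in the same direction as the pyrazolyl step, so the gap from compound 1 is no longer tied to one group: among these three compounds, the two with a hetero atom in the ring on this carbon read alike, and compound 1 stands apart. No measurement is available to account for these results.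

The compounds shown leave open whether the gap from compound 1 belongs to the trifluoromethyl group or to the carbon-only ring that carries it, which a plain phenyl on this carbon would separate. Also open, from the compounds shown here alone, is how a pyridin-2-yl ring bearing a dimethylamino group or a carboxylic acid would read in this assay against the unsubstituted ring of compound 3.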